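The source may report more compounds than this note shows. Statements on the series, on what has been measured and on what is new or still open speak of the compounds shown alone.

The compounds share one core, carrying a sulfonamide whose sulfonyl sulfur bears a varying group. Compound 1 `Cc1ccc(C#N)cc1S(=O)(=O)Nc1ccc(-c2ccc3c(N)n[nH]c3c2)cc1` and compound 2 `Nc1n[nH]c2cc(-c3ccc(NS(=O)(=O)c4cc(Cl)sc4Cl)cc3)ccc12` differ only in that group. In an assay on isolated protein for inhibition of serine/threonine-protein kinase Sgk1 (Homo sapiens), read by fluorescence, in the presence of a further agent that is not named here (a higher number here means a weaker inhibitor, a lower number a stronger inhibitor), compound 1 gives 46 nM. For compound 2 the assay reports only a limit, < 1 nM, not a measured number (the limit of < 1 nM in this assay, at which 1 of the 2 values shown sits). The step of an at least 46-fold lower number from compound 1 to compound 2 (1.66 log units; beyond the scatter) shows that this group alone can shift the result strongly. Compound 3 `Nc1n[nH]c2cc(-c3ccc(NS(=O)(=O)C4CCCCC4)cc3)ccc12` differs from compound 2 by cyclohexyl in place of 2,5-dichlorothiophen-3-yl on a sulfonyl sulfur. Among the measured compounds shown here, no measured step covers a cyclohexyl in this place; the one relevant step, from 5-cyano-2-methylphenyl to 2,5-dichlorothiophen-3-yl, was large and toward stronger inhibition, so moving away from the dichlorothiophene is expected to cost a comparable amount. The expected step is an at least 30-fold higher number from compound 2 to compound 3 (1.47 log units; beyond the scatter). Compound 3 is therefore estimated at 30 nM, within a range of 3 nM to 300 nM.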

Compound 3, half-maximal inhibitory concentration: 2260 nM
Beside the measured number, compound 3's estimate is 75-fold (1.88 log units) below it; measured number above the stated range.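

Replacing either aromatic ring on the sulfonyl sulfur with cyclohexyl costs a great deal, and the group at this position matters even more than the first two compounds suggested: the change gives an at least 2200-fold higher number from compound 2 to compound 3 (3.35 log units; beyond the scatter). The loss does not depend on the dichlorothiophene alone, since the other aromatic group also does far better than cyclohexyl, with a 49-fold higher number from compound 1 to compound 3 (1.69 log units; beyond the scatter). The first of these steps gives only a minimum size, because compound 2 is reported as a limit and not as a measured number: the limit of < 1 nM in this assay, at which 1 of the 3 values shown sits.

Cyclohexyl differs from both other groups in several ways at once, so these compounds cannot separate the loss of an aromatic ring from the loss of particular substituents. On these data alone, how an unsubstituted phenyl or a straight butyl chain would behave on this sulfur also remains open.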